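A few compounds are considered here, and "the series" means these few. Any claim that something is new, unique, unknown or untested is made for them only; others in the source may bear on it.

Measured so far in an in vitro functional assay on HEK293 cells for antagonist activity at melanin-concentrating hormone receptor 1 (Homo sapiens), read by GTPgammaS binding, with a stated time of 45 min; on this read-out higher numbers stand for weaker inhibition and lower numbers for stronger inhibition:
compound 1, `Cc1ccc(CN2CCC(NC(=O)NCc3ccc(-c4ccc(F)cc4)cc3)CC2)cc1`: 198 nM
compound 2, `COc1ccccc1-c1ccc(CNC(=O)NC2CCN(Cc3ccc(C)cc3)CC2)cc1`: 642 nM

Compound 1 gives the lowest of the two numbers in this assay. Its nearest neighbour is compound 2, reached by a 3.2-fold higher number from compound 1 to compound 2 (0.51 log units; beyond the scatter), a change on an aromatic carbon of the distal ring that leaves the urea untouched.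

Compound 3, `Cc1ccc(CN2CCC(NC(=O)N(CC(=O)C(C)(C)O)Cc3ccc(-c4ccc(F)cc4)cc3)CC2)cc1`, departs from compound 1 at a different place: ((1-hydroxy-1-methylethyl)carbonyl)methyl in place of hydrogen on an amide-type nitrogen. Within the data shown here, the only measured step alters the aromatic substituent, not the amide-type nitrogen, so no measured step bears directly on the change from compound 1 to compound 3. The urea hydrogen is carried unchanged by both compound 1 and compound 2, and nothing in the two values shows how this assay responds to its replacement.

The expectation for compound 3 therefore rests on compound 1 alone, and the expected step is a 2.0-fold higher number from compound 1 to compound 3 (0.31 log units; beyond the scatter), with a wide range in either direction. For compound 3 a value of 400 nM is estimated, between 100 nM and 1600 nM.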

Compound 3, antagonist equilibrium constant: 4530 nM
The estimate for compound 3 lay 11-fold (1.05 log units) below the measured number; measured number outside the range, above it.
By their numbers in this assay, from the lowest: compound 1; then compound 2; then compound 3.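

In this assay, the amide-type nitrogen whose other neighbours are the carbonyl carbon and a saturated chain carbon proves far from indifferent to substitution: ((1-hydroxy-1-methylethyl)carbonyl)methyl in place of hydrogen gives a 23-fold higher number from compound 1 to compound 3 (1.36 log units; beyond the scatter), a large step. Among these compounds, the only earlier step, a change on an aromatic carbon, was modest at a 3.2-fold higher number from compound 1 to compound 2 (0.51 log units; beyond the scatter), so this nitrogen is the more sensitive of the two places probed so far, although compound 3 still gives a measured number of 4530 nM in this assay. Nothing measured here shows what lies behind the step.

The compounds shown leave open whether a plain methyl on this nitrogen would move the number as far, or whether the step depends on the hydroxyl or the carbonyl of the entering group. Also open, going by these compounds, are how a chain ending in an amine or a carboxylic acid would read at this nitrogen, and whether the step would be of similar size with the 2-methoxyphenyl group of compound 2 in place of 4-fluorophenyl.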